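Aryl versus tert-butyl on the ring nitrogen: compound 4

The compounds below may be only part of what the source reports. "The series", "measured", "known", "first", "only" and "open" are said of these compounds alone.

Measured so far in an assay on isolated protein for inhibition of STE20-like serine/threonine-protein kinase (Homo sapiens), read by thermal shift assay, tested at 10 uM; on this read-out higher numbers stand for stronger stabilisation of the target against heat and lower numbers for weaker stabilisation of the target:
Compound 1 `Cc1ccc(-n2nc(C(C)(C)C)cc2NC(=O)Nc2cc(F)cc(F)c2)cc1` gives 2.8 degrees C.
Compound 2 `CC(C)(C)c1cc(NC(=O)Nc2cc(F)cc(F)c2)n(-c2ccc(F)cc2)n1` gives 2.7 degrees C.
Compound 3 `CC(C)(C)c1cc(NC(=O)Nc2cc(F)cc(F)c2)n(C(C)(C)C)n1` gives 0.2 degrees C.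

Compound 3 stands lowest of the three in this assay, beyond the scatter from both compound 2 and compound 1. Compounds 1 and 2 lie within the scatter of each other, so no order between them can be stated.

Compound 4 `CC(C)(C)c1cc(NC(=O)Nc2cc(F)cc(F)c2)n(-c2ccc(Br)cc2)n1` differs from compound 3 in one place: 4-bromophenyl in place of tert-butyl on an aromatic nitrogen.

For the measured compounds named here, two measured steps bear on this change, each running the opposite way: a number 2.6 degrees C lower from compound 1 to compound 3 (beyond the scatter) and a number 2.5 degrees C lower from compound 2 to compound 3 (beyond the scatter). In both, tert-butyl on the ring nitrogen in place of a substituted phenyl lowered the melting-temperature shift by a modest amount, and the two phenyl groups, differing only in their substituent, gave nearly the same result, as shown by a number 0.10 degrees C lower from compound 1 to compound 2 (within the scatter). Compound 4 restores a substituted phenyl on that nitrogen. Relative to compound 3, a modest rise in this assay is expected for compound 4, roughly the reverse of those two steps: a number 2.5 degrees C higher from compound 3 to compound 4 (beyond the scatter). Whether bromine on the phenyl behaves like methyl or fluorine there is not known from these data. Compound 4 is estimated at 2.7 degrees C, between 1.5 degrees C and 3.8 degrees C.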

Compound 4, shift of the target's melting temperature: 0.5 degrees C
Beside the measured number, compound 4's estimate is 2.2 degrees C above it, and the stated range ends above it.
By their numbers in this assay, from the lowest: compounds 3 and 4 (each within the scatter of the next); then compounds 2 and 1 (each within the scatter of the next).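

In this assay, restoring a substituted phenyl on the aromatic nitrogen does not by itself lift the number, since 4-bromophenyl and tert-butyl cannot be told apart at this position: a number 0.30 degrees C higher from compound 3 to compound 4 (within the scatter). The substituent on the phenyl ring therefore matters here, although methyl and fluoro could not be separated; with bromo the steps are a number 2.2 degrees C lower from compound 2 to compound 4 (beyond the scatter) and a number 2.3 degrees C lower from compound 1 to compound 4 (beyond the scatter). No measurement shown accounts for this difference between bromo and the other two substituents.

Going by these compounds, whether chloro, iodo or methoxy on the phenyl would group with bromo or with methyl and fluoro remains open, as does the place of an unsubstituted phenyl. A cyclohexyl group on the aromatic nitrogen is likewise an open case.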